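The compounds below may be only part of what the source reports. "The series", "measured", "known", "first", "only" and "open" are said of these compounds alone.

In a functional assay on A549 cells (Homo sapiens) for cytotoxicity, read by MTT assay, with a stated time of 24 h (on this read-out lower numbers stand for stronger inhibition and higher numbers for weaker inhibition), compound 1 `C=CC1=C(C(=O)NC(C)(C)C)C(c2ccc(OC)cc2)OC1` reaches only the limit of the assay, giving > 100000 nM. Compound 2 `C=CC1=C(C(=O)NCc2ccc(C)cc2)C(c2ccc(F)cc2)OC1` likewise sits at the limit in this assay, with > 100000 nM. Compound 3 `C=CC1=C(C(=O)NCc2ccc(C)cc2)C(c2ccc(OC)c(OC)c2)OC1` too gives a limit in this assay, namely > 100000 nM. Compound 1 therefore stands nowhere distinct: every value shown is a limit, as the limit of > 100000 nM in this assay, at which 3 of the 3 values shown sit, records. Compound 4 `C=CC1=C(C(=O)NCc2ccccc2)C(c2ccc(OC)cc2)OC1` differs from compound 1 by benzyl in place of tert-butyl on an amide-type nitrogen. For the measured compounds named here, no step between measured compounds is available, so the expected step from compound 1 to compound 4 is a number no higher from compound 1 to compound 4 (the limit leaves the size open), none beyond the scatter, because the limit of > 100000 nM in this assay, at which 3 of the 3 values shown sit, shows every compound at the same limit. Compound 4 is therefore expected to give about 100000 nM in this assay, between 30000 nM and 300000 nM, most probably again only a limit.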

Compound 4, half-maximal inhibitory concentration: > 100000 nM
Compound 4: a limit, no number; the forecaster's own chance of this, stated with the estimate: 80%; the middle value lies on the limit itself.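

No step can be read from compound 1 to compound 4, because both give only a limit: the limit of > 100000 nM in this assay, at which 4 of the 4 values shown sit. The compounds shown leave open what real values lie beyond that limit, and whether benzyl and tert-butyl differ at all.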